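Fluoro in place of hydrogen on compound 2

This account rests on a few compounds, and the source may have more. Where it says the series, first, only, none or still open, it means among the compounds named here.

- compound 1 `COc1ccc(C2=C(c3cc(OC)c(OC)c(OC)c3)C(=O)C(OC(C)=O)C2)cc1`: < 1 ug/mL
- compound 2 `COc1ccc(C2=C(c3cc(OC)c(OC)c(OC)c3)C(=O)C(O)C2)cc1`: < 1 ug/mL

In an ADME assay on MIA PaCa-2 cells (Homo sapiens) for cytotoxicity, read by MTT assay, with a stated time of 72 h (a higher number here means a weaker inhibitor, a lower number a stronger inhibitor), compound 2 gives < 1 ug/mL, which is a limit and not a number. Compound 1 gives < 1 ug/mL, also a limit. Among the measured compounds shown here, the whole series so far therefore rests on one reading: the limit of < 1 ug/mL in this assay, at which 2 of the 2 values shown sit.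

Compound 3 `COc1ccc(C2=C(c3cc(OC)c(OC)c(OC)c3)C(=O)C(O)C2)cc1F` differs from compound 2 by one change: fluoro in place of hydrogen on an aromatic carbon. The 4-methoxyphenyl thus becomes 3-fluoro-4-methoxyphenyl. For the measured compounds named here, the only measured step, a step that the two limits leave unreadable from compound 1 to compound 2, lies elsewhere on the molecule, and it gives no size to carry over to this change. No step beyond the scatter is therefore expected in this assay, in either direction. The estimated step is a step that the limit leaves unreadable from compound 2 to compound 3. Compound 3 is expected at 0.5 ug/mL, with an estimated range of 0.1 ug/mL to 1.5 ug/mL.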

Compound 3, half-maximal inhibitory concentration: 64 ug/mL
For compound 3 the middle estimate is 130-fold (2.11 log units) below the measured one; measured number outside the range, above it.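

In this assay, the change from 4-methoxyphenyl to 3-fluoro-4-methoxyphenyl gives an at least 64-fold higher number from compound 2 to compound 3 (1.80 log units; beyond the scatter), so this position, ortho to a methoxy group, does not tolerate even this single added fluoro without a marked weakening. Among the compounds shown here, the step between compound 1 and compound 2 cannot be read, which makes this the only readable step and compound 3 the only compound with a number rather than a limit. On these data alone, its true size remains unknown, and the printed step is only a minimum, because the reading for compound 2 is a limit: the limit of < 1 ug/mL in this assay, at which 2 of the 3 values shown sit.

As far as these compounds go, whether chloro, methyl or an amine at this position would also weaken the compound remains open. From the compounds shown here alone, it is equally open whether fluoro here would have the same effect with the acetyl group of compound 1 in place.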